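From Compound 1 to Compound 3: a Change Without Precedent

The source may hold more compounds than are shown below. What is called first, only, known or untested is meant among the compounds shown, and "the series" means these compounds.

Compound 1, `CC(C)OC(=O)N1CCC(Oc2ncnc3c2CCN3c2ccc(S(C)(=O)=O)cc2F)CC1`, was tested in a functional assay on CHO-K1 cells for agonist activity at Glucose-dependent insulinotropic receptor (Homo sapiens), read by a luciferase reporter, with a stated time of 5 h; a lower number here means that less compound is needed, a higher number that more compound is needed for the effect. In this assay compound 1 gives 50.1 nM, the highest of the two numbers recorded. Among the compounds with values here, its only neighbour is compound 2, `CS(=O)(=O)c1ccc(N2CCc3c(OC4CCN(C(=S)Sc5ccccc5)CC4)ncnc32)c(F)c1`, which in this assay gives 12.6 nM. Within the data shown here, the one measured step, a 4.0-fold lower number from compound 1 to compound 2 (0.60 log units; beyond the scatter), came from a group of 9 heavy atoms (7 carbon, 2 sulfur; one six-membered aromatic ring of carbon only) in place of a group of 6 heavy atoms (4 carbon, 2 oxygen; no ring), on an amine nitrogen in a ring.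

Compound 3, `CC(C)OC(=O)N1CCC(Oc2ncnc3c2CCN3c2ccc([S@+](C)[O-])c(F)c2)CC1`, departs from compound 1 at a different place: a group of 10 heavy atoms (7 carbon, 1 oxygen, 1 fluorine, 1 sulfur; one six-membered aromatic ring of carbon only) in place of a group of 11 heavy atoms (7 carbon, 2 oxygen, 1 fluorine, 1 sulfur; one six-membered aromatic ring of carbon only), on a nitrogen on an aromatic ring in a ring. Among the measured compounds shown here, no measured step touches this part of the shared core, so the step from compound 1 to compound 2 offers no guidance, and no direction beyond the scatter can be read from the data.

Compound 3 is therefore expected to give about 60 nM in this assay, between 15 nM and 250 nM. The expected step of a 1.2-fold higher number from compound 1 to compound 3 (0.08 log units; within the scatter) is estimated to stay within the scatter.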

Compound 3, half-maximal effective concentration: 50.1 nM
Estimate against measurement, compound 3: 1.2-fold (0.08 log units) above; measured number inside the range.
By their numbers in this assay, from the lowest: compound 2; then compounds 1 and 3 (each within the scatter of the next).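

Within the data shown here, at the nitrogen on an aromatic ring in a ring, this assay gives no change at the digits printed from compound 1 to compound 3 (within the scatter) as the only reading for this place. The 2-fluoro-4-(methylsulfonyl)phenyl group can therefore give way to a group with one oxygen fewer, 1 hydrogen-bond acceptor rather than 2 and 1 defined stereocentre, and the number stays within the scatter, whereas the earlier step of a 4.0-fold lower number from compound 1 to compound 2 (0.60 log units; beyond the scatter) concerned only the amine nitrogen in a ring. No supporting measurement accompanies this result, so it comes with no explanation.

The compounds shown leave open whether the other configuration of this stereocentre would read the same, and whether this exchange would hold on the core of compound 2. They also leave open how an aryl group carrying a nitrile, an amine or a carboxylic acid would behave at this place.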